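From 4-Chlorophenyl to Methyl on Compound 1

The compounds below may be only part of what the source reports. "The series", "measured", "known", "first", "only" and "open" are said of these compounds alone.

In a functional assay on HeLa cells (Homo sapiens) for cytotoxicity, read by MTT assay, with a stated time of 72 h (a higher number here means a weaker inhibitor, a lower number a stronger inhibitor), compound 1 `O=C(Nc1nnc(-c2cccc(O)c2O)s1)c1ccc(Cl)cc1` gives 13000 nM. Compound 2 `Cc1ccc(C(=O)Nc2nnc(-c3ccc(O)c(O)c3)s2)cc1` gives 67100 nM, and compound 3 `O=C(Nc1nnc(-c2ccc(O)c(O)c2)s1)C1CCCCC1` gives 34500 nM. Compound 1 thus holds the lowest of the three numbers, and its gap to each of the other two lies beyond the scatter.

Compound 4 `CC(=O)Nc1nnc(-c2cccc(O)c2O)s1` has not yet been measured. It keeps the core of compound 1 but has methyl in place of 4-chlorophenyl on a carbonyl carbon.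

Among the measured compounds shown here, only one measured step bears on this change: a 1.9-fold lower number from compound 2 to compound 3 (0.29 log units; within the scatter). It is a weak guide, as it exchanges one ring for another on a different core, whereas methyl has no ring. Compound 1 already has the lowest number, 13000 nM, so a moderate move toward a higher number is expected, with wide uncertainty. The expected change is a 2.7-fold higher number from compound 1 to compound 4 (0.43 log units; beyond the scatter). For compound 4, the estimated value is 35000 nM, within an expected range of 12000 nM to 100000 nM.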

Compound 4, half-maximal inhibitory concentration: 177000 nM
Compound 4: the middle estimate sits 5.1-fold (0.70 log units) below what was measured; measured number above the stated range.
By their numbers in this assay, from the lowest: compound 1; then compounds 3 and 2 (each within the scatter of the next); then compound 4.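

In this assay, the group on the carbonyl carbon of the core of compound 1 proves able to shift the number substantially: with methyl in place of 4-chlorophenyl, the result is a 14-fold higher number from compound 1 to compound 4 (1.13 log units; beyond the scatter). The earlier step, a 1.9-fold lower number from compound 2 to compound 3 (0.29 log units; within the scatter), exchanged one ring for another on a different core and stayed within the scatter, whereas this change removes the ring altogether and moves the number well beyond it. No available measurement accounts for the size of this step.

The change removes the ring and its chlorine together, leaving their separate contributions unresolved. Going by these compounds, whether unsubstituted phenyl or a longer chain such as butyl on this carbonyl carbon would give a number nearer that of compound 1 or that of compound 4 remains open.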